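Triazole substituent swap and tolerated concentration in MT4 cells

This account rests on a few compounds, and the source may have more. Where it says the series, first, only, none or still open, it means among the compounds named here.

Compound 1 `Cc1cc(C)c(Oc2cc(Nc3ccc(C#N)cc3)ncc2C(=O)NCc2cn(Cc3ccccc3F)nn2)c(C)c1`: in an ADME assay on MT4 cells (Homo sapiens) for cytotoxicity, read by MTT assay, with a stated time of 5 days (a higher number here means that more compound is tolerated, a lower number that less compound is tolerated), compound 1 sits at a limit, > 222000 nM.
Compound 2 `Cc1cc(C)c(Oc2cc(Nc3ccc(C#N)cc3)ncc2C(=O)NCc2cn(Cc3ccccc3Cl)nn2)c(C)c1`: in this assay compound 2 also sits at a limit, >= 188000 nM.
Compound 3 `Cc1cc(C)c(Oc2cc(Nc3ccc(C#N)cc3)ncc2C(=O)NCc2cn(CC(N)=O)nn2)c(C)c1`: in this assay compound 3 gives 24000 nM.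

Among the compounds with values here, compound 3 is thus the only compound of the three with an actual number; the other two values are limits, as recorded in the limit of > 222000 nM in this assay, at which 1 of the 3 values shown sits, and (the limit of >= 188000 nM in this assay, at which 1 of the 3 values shown sits). Compound 4 `Cc1cc(C)c(Oc2cc(Nc3ccc(C#N)cc3)ncc2C(=O)NCc2cn(Cc3cccc(Cl)c3)nn2)c(C)c1` differs from compound 3 in one place: 3-chlorophenyl in place of carbamoyl on a saturated chain carbon bound to an aromatic nitrogen. The measured steps that bear on this change run in the opposite direction, from an aryl group to carbamoyl: an at least 9.2-fold lower number from compound 1 to compound 3 (0.96 log units; beyond the scatter) and an at least 7.8-fold lower number from compound 2 to compound 3 (0.89 log units; beyond the scatter). The chloro-for-fluoro step is not readable because of the two limits: a step that the two limits leave unreadable from compound 1 to compound 2. Since compound 3 came out lower than both aryl analogues, restoring an aryl group in compound 4 is expected to raise the number again, very possibly back to a limit. Compound 4 is therefore estimated at 180000 nM, within a range of 60000 nM to 400000 nM. The expected step is a 7.5-fold higher number from compound 3 to compound 4 (0.88 log units; beyond the scatter).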

Compound 4, half-maximal cytotoxic concentration: 187000 nM
For compound 4 the middle estimate is 1.0-fold (0.02 log units) below the measured one; the measured number falls inside the stated range.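

Within the data shown here, the change from carbamoylmethyl to 3-chlorobenzyl, 3-chlorophenyl in place of carbamoyl on a saturated chain carbon bound to an aromatic nitrogen, is the only step at this position with actual numbers at both ends, and in this assay it reads as a modest step: a 7.8-fold higher number from compound 3 to compound 4 (0.89 log units; beyond the scatter). Against the 2-fluorophenyl group, the 3-chlorophenyl group gives an at least 1.1-fold lower number from compound 1 to compound 4 (0.07 log units; that floor lies within the scatter), a floor that does not separate the two groups. Against the 2-chlorophenyl group, the 3-chlorophenyl group gives a number no higher from compound 2 to compound 4 (the limit leaves the size open). The size of that step cannot be read because compound 2 sits at a limit: the limit of >= 188000 nM in this assay, at which 1 of the 4 values shown sits.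

The compounds shown leave open whether the higher number requires an aromatic ring at all, or whether a longer saturated chain, an amine or a carboxylic acid on the same saturated chain carbon would give a similar number. They also leave open whether the 2-chlorophenyl and 3-chlorophenyl groups differ in this assay at all.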